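The source may report more compounds than this note shows. Statements on the series, on what has been measured and on what is new or still open speak of the compounds shown alone.

Measured compounds in a functional assay on PC-3 cells (Homo sapiens) for cytotoxicity, read by MTT assay, with a stated time of 48 h, in the absence of a further agent; on this read-out higher numbers stand for weaker inhibition and lower numbers for stronger inhibition:

compound 1, `O=C(Nc1ccccc1)c1csc(-c2cn(Cc3ccc(Cl)cc3)c3ccccc23)n1`: 76400 nM
compound 2, `O=C(Nc1ccccc1)c1csc(-c2c[nH]c3ccccc23)n1`: a limit, > 100000 nM
compound 3, `COc1ccc(NC(=O)c2csc(-c3c[nH]c4ccc(F)cc34)n2)cc1`: a limit, > 100000 nM

Compound 2 sits at the limit of this assay, where no number is reported; the value for compound 2 is > 100000 nM. Compound 3 also sits at a limit, > 100000 nM. For the measured compounds named here, compound 1 is the only compound of the three with a number, and it is weak. Going by the values given here, the one measured step, an at least 1.3-fold higher number from compound 1 to compound 2 (0.11 log units; that floor lies within the scatter), runs from a number into a limit and is small. The limit of > 100000 nM in this assay, at which 2 of the 3 values shown sit, is where most of the series rests.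

Compound 4, `Cc1ccc(NC(=O)c2csc(-c3c[nH]c4ccccc34)n2)cc1`, is not yet measured. It differs from compound 2 by methyl in place of hydrogen on an aromatic carbon, a change on the anilide ring rather than on the aromatic nitrogen, so the measured step does not bear on it directly. Compound 3, carrying a methoxy on the same ring as well as a fluoro elsewhere, still sits at a limit. Compound 4 is therefore expected to stay close to the limit, with a step that the limit leaves unreadable from compound 2 to compound 4 if a number appears at all. The estimate for compound 4 in this assay is 120000 nM, in the range 50000 nM to 300000 nM.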

Compound 4, half-maximal inhibitory concentration: > 100000 nM
Compound 4: a limit, no number; the forecaster's own chance of this, stated with the estimate: 70%; the middle value lies beyond the limit too.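

In this assay compound 4 gives > 100000 nM, a limit and not a number, and compound 2 also sits at a limit, so no step between compound 2 and compound 4 can be read: the limit of > 100000 nM in this assay, at which 3 of the 4 values shown sit.

Going by these compounds, whether methyl in place of hydrogen changes the read-out at all, and in which direction, stays open.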